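The compounds below may be only part of what the source reports. "The series", "measured", "known", "first", "only" and "open" are said of these compounds alone.

Of the compounds shown here, three on a shared core have been measured in a functional assay on L1210 cells (Mus musculus), with a stated time of 12 days; on this read-out higher numbers stand for higher potency (the scale is a negative logarithm) and lower numbers for lower potency. Compound 1 `COCCC1=C(N2CC2)C(=O)C(C)=C(N2CC2)C1=O` gives 5.57, the lowest of the three numbers. Compound 3 `CCC(OC)C1=C(N2CC2)C(=O)C(C)=C(N2CC2)C1=O` gives 5.68, and the step of a number 0.11 log units higher from compound 1 to compound 3 (within the scatter) lies within the scatter, so these two are not told apart. Compound 2 `CC1=C(N2CC2)C(=O)C(C(C)COC(N)=O)=C(N2CC2)C1=O` gives 6.41; the step of a number 0.84 log units higher from compound 1 to compound 2 (beyond the scatter) is the one clear movement in the set, and the step of a number 0.73 log units lower from compound 2 to compound 3 (beyond the scatter) shows the same gap from the other side.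

Compound 4 `CC1=C(N2CC2)C(=O)C(COc2ccccc2)=C(N2CC2)C1=O` has not yet been measured. It differs from compound 1 in one place: phenoxy in place of methoxymethyl on a saturated chain carbon bound to a double-bonded ring carbon. Among the compounds with values here, no measured step exchanges a chain for a phenoxy group, so none bears directly on this change; the two measured steps that alter the same chain are a number 0.84 log units higher from compound 1 to compound 2 (beyond the scatter), where a larger group entered, and a number 0.11 log units higher from compound 1 to compound 3 (within the scatter), where the chain was only rearranged. For compound 4 a modest rise is therefore expected, the step of a number 0.33 log units higher from compound 1 to compound 4 (beyond the scatter). Compound 4 is estimated to give 5.9, between 5.3 and 6.6.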

Compound 4, logarithm of the reciprocal of the active concentration, log(1/C): 5.15
Beside the measured number, compound 4's estimate is 0.75 log units above it, and the stated range ends above it.
By their numbers in this assay, from the lowest: compound 4; then compounds 1 and 3 (each within the scatter of the next); then compound 2.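

The change from methoxymethyl to phenoxy gives a number 0.42 log units lower from compound 1 to compound 4 (beyond the scatter) in this assay, so a larger group at this place does not by itself raise the number. The same chain position can move in either direction: the step of a number 0.84 log units higher from compound 1 to compound 2 (beyond the scatter) goes up with a larger group that has no ring, while the new step goes down with a group that carries a six-membered aromatic ring of carbon only. No measurement shown explains why phenoxy lowers the number here.

On these data alone, it remains open whether the aromatic ring or the oxygen attached to it goes with the drop, which a benzyl group in place of phenoxy could help separate. It is also unknown how an amine or a carboxylic acid at the end of this chain would compare.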